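This account rests on a few compounds, and the source may have more. Where it says the series, first, only, none or still open, it means among the compounds named here.

Measured compounds:
- compound 1, `CC(C)C(=O)N1CC2CC(C1)N2`: 86%
- compound 2, `O=C([C@H]1C[C@H]1F)N1CC2CC(C1)N2`: 110%
- compound 3, `O=C([C@H]1C[C@@H]1F)N1CC2CC(C1)N2`: 100%

All three share one core and differ only in the group on the carbonyl carbon. In an assay on SH-EP1 cells for agonist activity at Neuronal acetylcholine receptor; alpha4/beta2 (Homo sapiens), read by FLIPR and calcium flux (on this read-out lower numbers stand for smaller maximal responses and higher numbers for larger maximal responses), compound 1 gives 86%. Putting 2-fluorocyclopropyl in place of isopropyl raised the response: a number 24 percentage points higher from compound 1 to compound 2 (beyond the scatter) and a number 14 percentage points higher from compound 1 to compound 3 (beyond the scatter). Between the two fluorocyclopropyl compounds the step was a number 10 percentage points lower from compound 2 to compound 3 (within the scatter), so compound 3 stands second of the three numbers, close to compound 2 and clearly above compound 1.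

The next compound, compound 4, `O=C([C@@H]1C[C@H]1F)N1CC2CC(C1)N2`, is to be measured in this assay. It differs from compound 3 only in how the stereocentres are drawn: the two compounds have the same atoms and bonds; at least one stereo element is drawn with a configuration in one of them and without one in the other: 2 of 4 stereo elements differ; a stereocentre at a saturated ring carbon is drawn R in compound 3 and S in compound 4; a stereocentre at a saturated ring carbon is drawn S in compound 3 and R in compound 4. Among the compounds with values here, the one step of the same kind already seen, from compound 2 to compound 3, stayed within the scatter, so no change beyond the scatter is expected here either: the expected step is no change at the digits printed from compound 3 to compound 4 (within the scatter). Compound 4 is therefore estimated at 100%, in the range 85% to 115%.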

Compound 4, largest response reached (Emax), in percent of the reference or control that the assay uses: 110%
Compound 4: middle estimate off by 10 percentage points, on the low side; measured number inside the range.
By their numbers in this assay, from the lowest: compound 1; then compounds 3, 2 and 4 (each within the scatter of the next).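

In this assay, inverting both stereocentres of the 2-fluorocyclopropyl group at once still leaves the response within the scatter, with a number 10 percentage points higher from compound 3 to compound 4 (within the scatter). Changing a single stereocentre gives the same picture, with no change at the digits printed from compound 2 to compound 4 (within the scatter), so the maximal response does not separate the three stereo forms shown. The third form also keeps the gain over isopropyl, with a number 24 percentage points higher from compound 1 to compound 4 (beyond the scatter), and no fluorocyclopropyl compound shown goes against this pattern.

The compounds shown leave open whether the gain comes from the three-membered ring or from the fluorine, which a plain cyclopropyl group on the carbonyl carbon would help to separate. They also leave open whether the remaining arrangement of the two stereocentres would fit the same pattern.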